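This account rests on a few compounds, and the source may have more. Where it says the series, first, only, none or still open, it means among the compounds named here.

Measured so far in a functional assay (muscle tissue) with Cavia porcellus as the target; on this read-out higher numbers stand for an effect only at larger amounts of compound and lower numbers for an effect already at smaller amounts:
compound 1 `COC(=O)C1=C(C)N=C(C)/C(=C(\O)OC)C1c1ccccc1C`: 6.03 nM
compound 2 `COC(=O)C1=C(C)N=C(C)/C(=C(\O)OC)C1c1cccc(OC)c1`: 191 nM
compound 3 `COC(=O)C1=C(C)N=C(C)/C(=C(\O)OC)C1c1cccc(F)c1`: 20.9 nM

Compound 3 holds the second highest of the three numbers in this assay. Its nearer neighbour is compound 1, as a 3.5-fold higher number from compound 1 to compound 3 (0.54 log units; beyond the scatter) shows; its further neighbour is compound 2, as a 9.1-fold lower number from compound 2 to compound 3 (0.96 log units; beyond the scatter) shows.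

Compound 4 `COC(=O)C1=C(C)N=C(C)/C(=C(\O)OC)C1c1ccccc1OC` has not yet been measured. 2-methoxyphenyl in place of 3-fluorophenyl on a saturated ring carbon

Among the measured compounds shown here, two measured steps bear on this change. The exchange of fluoro for methoxy on an aromatic carbon gave a 9.1-fold lower number from compound 2 to compound 3 (0.96 log units; beyond the scatter), a methoxy-bearing ring having the higher number. On the other hand, the ring bearing the substituent in the 2-position, compound 1, gives the lowest number of the three, and a 32-fold higher number from compound 1 to compound 2 (1.50 log units; beyond the scatter) shows how much higher the number went when 3-methoxyphenyl replaced 2-methylphenyl. For the measured compounds named here, no measured pair contains 2-methoxyphenyl itself, so the two tendencies cannot be separated.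

Weighing both, compound 4 is expected to give about 12 nM in this assay, between 3 nM and 50 nM. This estimate means a step of a 1.7-fold lower number from compound 3 to compound 4 (0.24 log units; within the scatter), expected to lie within or close to the scatter.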

Compound 4, half-maximal effective concentration: 57.5 nM
Estimate against measurement, compound 4: 4.8-fold (0.68 log units) below; measured number above the stated range.
By their numbers in this assay, from the lowest: compound 1; then compound 3; then compound 4; then compound 2.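

In this assay, the place of the methoxy group on the phenyl ring now counts by itself: 2-methoxyphenyl in place of 3-methoxyphenyl gives a 3.3-fold lower number from compound 2 to compound 4 (0.52 log units; beyond the scatter), while the fluoro and methoxy comparison had involved only the 3-substituted rings. The low number of compound 1 is not carried by the place of the substituent alone, since methoxy in place of methyl gives a 9.5-fold higher number from compound 1 to compound 4 (0.98 log units; beyond the scatter), and 2-methoxyphenyl in place of 3-fluorophenyl still gives a 2.8-fold higher number from compound 3 to compound 4 (0.44 log units; beyond the scatter). Nothing available accounts for these differences.

What the compounds shown leave open is whether 2-fluorophenyl would also give a lower number than 3-fluorophenyl, as the methoxy pair does. Going by these compounds, how a chloro or nitro group on the phenyl ring would read also remains open.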